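This account rests on a few compounds, and the source may have more. Where it says the series, first, only, none or still open, it means among the compounds named here.

Compound 1: `CC1CCN(c2nc(C(F)(F)F)ccc2CNC(=O)Nc2ccc3cnncc3c2)CC1` — 8.9 nM
Compound 2: `CC1CCN(c2nc(C(F)(F)F)ccc2CNC(=O)Nc2cccc3cccnc23)CC1` — 91.6 nM

In an assay on isolated protein for antagonist activity at transient receptor potential cation channel subfamily V member 1 (Homo sapiens), read by FLIPR (on this read-out lower numbers stand for stronger inhibition and higher numbers for weaker inhibition), compound 2 gives the higher of the two numbers, and compound 1 gives the lower one, the step of a 10-fold higher number from compound 1 to compound 2 (1.01 log units; beyond the scatter) being large. Compound 3, `CC1CCN(c2nc(C(F)(F)F)ccc2CNC(=O)Nc2cccc3cnccc23)CC1`, carries isoquinolin-5-yl in place of quinolin-8-yl on an amide-type nitrogen. Among the measured compounds shown here, only that one step bears on the change, and it shows that reshaping this ring system can move the number a long way in either direction. Because of the size of a 10-fold higher number from compound 1 to compound 2 (1.01 log units; beyond the scatter), compound 3 is expected to land somewhere between the two measured values, the estimated step being a 3.1-fold lower number from compound 2 to compound 3 (0.48 log units; beyond the scatter). Compound 3 is therefore estimated at 30 nM, within 7 nM to 130 nM.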

Compound 3, inhibition constant: 0.2 nM
Compound 3: middle estimate off by 150-fold (2.18 log units), on the high side; the measured number lies below the stated range.
By their numbers in this assay, from the lowest: compound 3; then compound 1; then compound 2.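

In this assay, the same atoms joined differently on the amide-type nitrogen, isoquinolin-5-yl in place of quinolin-8-yl, give a very large change (a 460-fold lower number from compound 2 to compound 3 (2.66 log units; beyond the scatter)). The number here therefore depends on how this group is arranged, not only on which atoms it holds, and the lowest number shown also shifts (a 45-fold lower number from compound 1 to compound 3 (1.65 log units; beyond the scatter)). Nothing measured here explains why.

Going by these compounds, what stays open is how a naphthyl group, with carbon only in both rings, would compare on this nitrogen. It would show how much the ring nitrogen itself matters.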